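The compounds below may be only part of what the source reports. "The series", "measured", "known", "first", "only" and "open" are said of these compounds alone.

Of the compounds shown here, two have so far been measured in a functional assay on T47D cells (Homo sapiens) for inhibition, read by sulforhodamine B assay, with a stated time of 48 h; a lower number here means a stronger inhibitor of growth, a higher number a weaker inhibitor of growth. Compound 1 `COC(=O)[C@@]1(C)CCC=C2[C@@H]1CC[C@@H](C)[C@]2(C)Cc1c[nH]c2ccc(C(F)(F)F)cc12` gives 15000 nM. Compound 2 `COC(=O)[C@@]1(C)CCC=C2[C@@H]1CC[C@@H](C)[C@]2(C)Cc1c(C)[nH]c2ccc(Cl)cc12` gives 17000 nM in this assay. The gap between compound 1 and compound 2 lies within the usual scatter of repeated measurements, so on these numbers the two cannot be told apart. Compound 3 `COC(=O)[C@@]1(C)CCC=C2[C@@H]1CC[C@@H](C)[C@]2(C)Cc1c(C)[nH]c2ccc(C(F)(F)F)cc12` has not yet been measured. It differs from compound 2 in one place: trifluoromethyl in place of chloro on an aromatic carbon. A trifluoromethyl group already sits on compound 1, which lacks the methyl found on compound 2 and compound 3. Among the measured compounds shown here, no single-change step between measured compounds is available, so the size of the step can only be estimated. Because compound 1 with its value of 15000 nM sits close to compound 2, no step beyond the scatter is expected from compound 2 to compound 3, in either direction. Compound 3 is therefore estimated at 15000 nM, within a range from 7000 nM to 32000 nM, which means an expected step of a 1.1-fold lower number from compound 2 to compound 3 (0.05 log units; within the scatter).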

Compound 3, concentration for 50% growth inhibition: 21000 nM
Beside the measured number, compound 3's estimate is 1.4-fold (0.15 log units) below it; low and high end bracket the measured number.
By their numbers in this assay, from the lowest: compounds 1, 2 and 3 (each within the scatter of the next).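

In this assay, putting trifluoromethyl in place of chloro on this aromatic carbon gives a 1.2-fold higher number from compound 2 to compound 3 (0.09 log units; within the scatter) and so the two groups cannot be told apart here, although trifluoromethyl carries more heavy atoms. Among the compounds shown here, compound 3 also supplies the first pair that differs only by methyl in place of hydrogen on an aromatic carbon, and this gives a 1.4-fold higher number from compound 1 to compound 3 (0.15 log units; within the scatter) so this change, too, cannot be told from no change at all. Nothing on hand offers an explanation for either result.

The compounds shown leave open whether any group on this aromatic carbon can move the number beyond the scatter. An amine or a carboxylic acid in place of the trifluoromethyl, or a longer chain in place of the methyl, would test how far this flat picture holds.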